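This account rests on a few compounds, and the source may have more. Where it says the series, first, only, none or still open, it means among the compounds named here.

Measured so far in an ADME assay on MT2 cells (Homo sapiens) for cytotoxicity, read by XTT assay, with a stated time of 4 days; on this read-out higher numbers stand for lower toxicity in this test and lower numbers for higher toxicity in this test:
Compound 1, `Cc1nc(C(NC(=O)C(=O)Nc2ccc(F)c(F)c2)C2CCCCN2)sc1CO`, gives > 87000 nM, which is a limit of the test and not a number.
Compound 2, `CC(=O)c1ccc(NC(=O)C(=O)NC(c2nc(C)c(CCO)s2)C2CCCCN2)cc1`, gives > 48300 nM, likewise a limit.

Within the data shown here, compound 1 stands at a limit in this assay, (the limit of > 87000 nM in this assay, at which 1 of the 2 values shown sits), and the only other value shown is also a limit, (the limit of > 48300 nM in this assay, at which 1 of the 2 values shown sits). Compound 3, `Cc1ccc(NC(=O)C(=O)NC(c2nc(C)c(CO)s2)C2CCCCN2)cc1F`, differs from compound 1 by methyl in place of fluoro on an aromatic carbon. Among the measured compounds shown here, with no step between measured compounds known, the expected change a step that the limit leaves unreadable from compound 1 to compound 3 is none beyond the scatter. Compound 3 is expected to give 90000 nM, between 40000 nM and 200000 nM, most probably again as a limit.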

Compound 3, half-maximal cytotoxic concentration: > 88000 nM
Compound 3 ended at the assay's limit; the forecaster's own chance of this, stated with the estimate: 85%; the middle value does not contradict the limit.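

No step can be read between compound 1 and compound 3, as both results in this assay are limits of the test. The compounds shown leave open whether methyl in place of fluoro changes the read-out at all.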